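Trading a ring-bound amine for an open-chain amine

The source may hold more compounds than are shown below. What is called first, only, known or untested is meant among the compounds shown, and "the series" means these compounds.

Measured in a functional assay on MCF7 cells (Homo sapiens) for antiproliferative activity; on this read-out higher numbers stand for weaker inhibition and lower numbers for stronger inhibition:
compound 1, `CC(C)=CCc1cc(C(=O)Nc2cc3ccc(OCCC4CCCCN4)c(C)c3oc2=O)ccc1O`, 710 nM
compound 2, `CC(C)=CCc1cc(C(=O)Nc2cc3ccc(OCC4CCCN(C)C4)c(C)c3oc2=O)ccc1O`, 2640 nM
compound 3, `CCCN(CCC)CCCOc1ccc2cc(NC(=O)c3ccc(O)c(CC=C(C)C)c3)c(=O)oc2c1C`, a limit of the assay: > 50000 nM

Compound 2 holds the highest of the two numbers that were read as values; its nearest neighbour is compound 1, and the step of a 3.7-fold higher number from compound 1 to compound 2 (0.57 log units; beyond the scatter) lies beyond the scatter. Compound 3 reached only the limit at which (the limit of > 50000 nM in this assay, at which 1 of the 3 values shown sits).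

The compound not yet measured is compound 4, `CC(C)=CCc1cc(C(=O)Nc2cc3ccc(OCCCN(C)C4CCCCC4)c(C)c3oc2=O)ccc1O`. Compared with compound 2 it carries 2-(cyclohexyl(methyl)amino)ethyl in place of 1-methylpiperidin-3-yl on a saturated chain carbon bound to an oxygen on an aromatic ring. The ring with its nitrogen is gone; what enters is a chain amine bearing a cyclohexyl and a methyl, the carbon ring now set apart from the nitrogen.

Within the data shown here, two measured steps bear on this. The move an at least 18-fold higher number from compound 2 to compound 3 (1.27 log units; beyond the scatter) also replaced the 1-methylpiperidin-3-yl with an open-chain tertiary amine, and an at least 70-fold higher number from compound 1 to compound 3 (1.84 log units; beyond the scatter) points the same way from the other ring amine. Both are large losses. Compound 4 keeps a six-membered ring, unlike compound 3, so the loss is expected to be smaller, but a clear weakening in this assay is still expected, a 5.7-fold higher number from compound 2 to compound 4 (0.75 log units; beyond the scatter).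

The estimate for compound 4 is 15000 nM, expected to fall between 4000 nM and 50000 nM.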

Compound 4, half-maximal inhibitory concentration: 1080 nM
For compound 4 the middle estimate is 14-fold (1.14 log units) above the measured one, and the stated range ends above it.
By their numbers in this assay, from the lowest: compounds 1 and 4 (each within the scatter of the next); then compound 2. At a limit, above all of these: compound 3.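

In this assay a ring-bound amine proves not to be required at this position: the open-chain 2-(cyclohexyl(methyl)amino)ethyl brings a 2.4-fold lower number from compound 2 to compound 4 (0.39 log units; beyond the scatter) instead of a loss, and the step of a 1.5-fold higher number from compound 1 to compound 4 (0.18 log units; within the scatter) leaves the two compounds indistinguishable. Open-chain amines are not alike here, and compound 3 is the one that goes against this result: cyclohexyl(methyl)amino in place of dipropylamino gives an at least 46-fold lower number from compound 3 to compound 4 (1.66 log units; beyond the scatter) on an otherwise unchanged molecule, so the groups carried on the chain nitrogen make a large difference. The figure for compound 3 is a limit of the assay, not a number: the limit of > 50000 nM in this assay, at which 1 of the 4 values shown sits.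

The compounds shown leave open whether the gain depends on the cyclohexyl ring itself, which a cyclopentyl or a phenyl on the same nitrogen would help to settle, along with an ethyl in place of the methyl. They also leave open how this amine behaves on a different link to the core, such as a shorter ethoxy or a longer butoxy chain.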